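The source may report more compounds than this note shows. Statements on the series, on what has been measured and on what is new or still open speak of the compounds shown alone.

Measured so far:
compound 1 `CN(C)CCCCCSC1=Nc2ccccc2C(CC(=O)NCc2ccccc2)N1c1ccc(-c2ccc(F)cc2)cc1` — 75.6%
compound 2 `O=C(CC1c2ccccc2N=C(SCCCCCN2CCCC2)N1c1ccc(-c2ccccc2)cc1)NCc1ccc(F)cc1` — 69%
compound 3 `CN(C)CCCCCSC1=Nc2ccccc2C(CC(=O)NCc2ccccc2)N1c1ccc(-c2ccccc2)cc1` — 83.9%

All three share one core and were tested in an assay on cells for inhibition of Voltage-dependent T-type calcium channel subunit alpha-1H (Homo sapiens), read by patch clamp, tested at 10 uM; a higher number here means more inhibition at the concentration tested (going by the name of the read-out), a lower number less inhibition. In this assay compound 3 gives 83.9%, and compound 1 gives 75.6%, a value within the scatter of compound 3. Compound 2 gives 69%, which lies beyond the scatter below compound 3.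

Compound 4 `CN(C)CCCCCSC1=Nc2ccccc2C(CC(=O)NCc2ccc(F)cc2)N1c1ccc(-c2ccccc2)cc1` has not yet been measured. It differs from compound 3 by fluoro in place of hydrogen on an aromatic carbon. Within the data shown here, the only step that bears on this is a number 8.3 percentage points higher from compound 1 to compound 3 (within the scatter), which concerns the same kind of swap on a different ring and stayed within the scatter. Compound 2 also carries this fluoro on the benzyl group but differs from compound 3 in a second place as well, so its lower number cannot be assigned to the fluoro alone.

The expected step from compound 3 to compound 4 is therefore small, a number 4.9 percentage points lower from compound 3 to compound 4 (within the scatter), in no clear direction. Compound 4 is estimated to give 79%, between 64% and 92%.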

Compound 4, a percentage reported as inhibition, at one concentration (the size of the read-out at that concentration, not a potency): 83.1%
Estimate against measurement, compound 4: 4.1 percentage points below; the measured number falls inside the stated range.
By their numbers in this assay, from the lowest: compounds 2, 1, 4 and 3 (each within the scatter of the next, the first and the last beyond it).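

In this assay, the change from benzyl to 4-fluorobenzyl gives a number 0.8 percentage points lower from compound 3 to compound 4 (within the scatter), so fluoro in place of hydrogen at this position makes no readable difference, as on the other aromatic ring. With that 4-fluorobenzyl group held constant, the amine at the end of the chain gives a number 14.1 percentage points higher from compound 2 to compound 4 (beyond the scatter), which ties the lower number of compound 2 to its pyrrolidin-1-yl group rather than to the fluoro. No measurement here explains either step.

The compounds shown leave open whether this gap between the two amines would persist with a piperidin-1-yl or morpholin-4-yl group, or with a shorter chain carrying dimethylamino. They also leave open whether chloro or methoxy on the benzyl ring would stay within the scatter of hydrogen, as fluoro does.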